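Furan-2-yl to furan-3-yl on a weak nucleoside

The compounds below may be only part of what the source reports. "The series", "measured", "known", "first", "only" and "open" are said of these compounds alone.

In a functional assay on A549 cells (Homo sapiens), read by MTT assay, with a stated time of 72 h (on this read-out lower numbers stand for stronger inhibition and higher numbers for weaker inhibition), compound 3 (`COc1nc(N)nc2c1c(-c1ccco1)cn2[C@@H]1O[C@H](CO)[C@@H](O)[C@H]1O`) gives > 20000 nM, which is a limit and not a number. Compound 1 (`Cc1ncnc2c1c(-c1ccsc1)cn2[C@@H]1O[C@H](CO)[C@@H](O)[C@H]1O`) gives > 20000 nM, also a limit. Compound 2 (`Nc1nc(N)c2c(-c3ccco3)cn([C@@H]3O[C@H](CO)[C@@H](O)[C@H]3O)c2n1`) gives > 20000 nM, again a limit. Compound 3 thus stands with the other two compounds at one shared mark, (the limit of > 20000 nM in this assay, at which 3 of the 3 values shown sit).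

Compound 4 (`COc1nc(N)nc2c1c(-c1ccoc1)cn2[C@@H]1O[C@H](CO)[C@@H](O)[C@H]1O`) is still unmeasured and has furan-3-yl in place of furan-2-yl on an aromatic carbon. Going by the values given here, the only measured step, a step that the two limits leave unreadable from compound 2 to compound 3, concerns methoxy in place of amino rather than the furan, and its size cannot be read. Among the compounds with values here, no measured step therefore gives a size to carry over, and no shift beyond the scatter is expected. The expected change is a number no higher from compound 3 to compound 4 (the limit leaves the size open), and compound 4 will most likely also be reported only as a limit. For compound 4 the estimate is 20000 nM, with an expected range from 10000 nM to 40000 nM.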

Compound 4, half-maximal inhibitory concentration: > 20000 nM
Compound 4 was reported as a limit; the forecaster's own chance of this, stated with the estimate: 85%; the middle value lies on the limit itself.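

The step from compound 3 to compound 4, furan-3-yl in place of furan-2-yl, cannot be read, as both values are limits and not numbers: the limit of > 20000 nM in this assay, at which 4 of the 4 values shown sit.

The compounds shown leave open what true value lies behind each limit, and whether the two furan groups differ at all.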